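Swapping the Amine Ring on a Longer Chain

This account rests on a few compounds, and the source may have more. Where it says the series, first, only, none or still open, it means among the compounds named here.

Compound 1 `O=c1cc(-c2ccccc2)oc2c(OCCCN3CCCC3)c(OCc3ccccc3)cc(O)c12` gives 7980 nM in a functional assay on B16 cells (Mus musculus) for cytotoxicity, read by MTT assay, with a stated time of 72 h; a higher number here means a weaker inhibitor, a lower number a stronger inhibitor.
Compound 2 `CN1CCN(CCCOc2c(OCc3ccccc3)cc(O)c3c(=O)cc(-c4ccccc4)oc23)CC1` gives 3760 nM in this assay.
Compound 3 `O=c1cc(-c2ccccc2)oc2c(OCCCCN3CCCC3)c(OCc3ccccc3)cc(O)c12` gives 3210 nM in this assay.

These three compounds share one core and differ only in the amine ring at the end of a chain that hangs from an oxygen on an aromatic ring. Compound 4 `CN1CCN(CCCCOc2c(OCc3ccccc3)cc(O)c3c(=O)cc(-c4ccccc4)oc23)CC1` has not yet been measured in this assay.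

The change from compound 1 to compound 2 is 4-methylpiperazin-1-yl in place of pyrrolidin-1-yl on a saturated chain carbon, three bonds along the chain from an oxygen on an aromatic ring. In this assay it produced a 2.1-fold lower number from compound 1 to compound 2 (0.33 log units; beyond the scatter). The core of compound 3 differs from the core of compound 1 by (pyrrolidin-1-yl)methyl in place of pyrrolidin-1-yl on a saturated chain carbon, three bonds along the chain from an oxygen on an aromatic ring, which gave a 2.5-fold lower number from compound 1 to compound 3 (0.40 log units; beyond the scatter); between compound 2 and compound 3 the numbers show a 1.2-fold lower number from compound 2 to compound 3 (0.07 log units; within the scatter).

The change from compound 3 to compound 4 is 4-methylpiperazin-1-yl in place of pyrrolidin-1-yl on a saturated chain carbon, four bonds along the chain from an oxygen on an aromatic ring. The place is not identical: in the first pair the amine ring sits three bonds along the chain from the oxygen, in the second pair four bonds along. It is therefore the same kind of change, not the same change.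

In this assay the step is expected to be a 1.6-fold lower number from compound 3 to compound 4 (0.21 log units; within the scatter), resting on the earlier pair where compound 1 to compound 2 showed a 2.1-fold lower number from compound 1 to compound 2 (0.33 log units; beyond the scatter). Going by the values given here, with only one earlier example and a different chain length, a good deal of uncertainty remains. Compound 4 is expected to give about 2000 nM, most likely between 900 nM and 4500 nM.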

Compound 4, half-maximal inhibitory concentration: 2370 nM
Compound 4: middle estimate off by 1.2-fold (0.07 log units), on the low side, within the range that was stated.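

In this assay, 4-methylpiperazin-1-yl in place of pyrrolidin-1-yl on the longer chain gives a 1.4-fold lower number from compound 3 to compound 4 (0.13 log units; within the scatter), so compound 3 and compound 4 cannot be told apart on this measure, even though the same swap on the shorter chain gave a step beyond the scatter. Set side by side, the two steps give no sign that the swap behaves differently on the two cores: the same change on two cores in this assay, a 2.1-fold lower number (0.33 log units; beyond the scatter) from compound 1 to compound 2 and a 1.4-fold lower number (0.13 log units; within the scatter) from compound 3 to compound 4, 1.6-fold (0.20 log units) apart, within the scatter of two such steps. This is agreement between only two pairs, so it does not show that the swap has a fixed size on every core in the series, and the chain also matters little at this level of detail in one case: with the 4-methylpiperazin-1-yl ring kept, the longer chain gives a 1.6-fold lower number from compound 2 to compound 4 (0.20 log units; within the scatter), whereas changing ring and chain together gives a 3.4-fold lower number from compound 1 to compound 4 (0.53 log units; beyond the scatter), the largest step among these compounds.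

The compounds shown leave open whether the swap would hold on a still longer chain or a shorter one. They also leave open how other amine rings, such as morpholine or piperidine, or an open-chain amine such as dimethylamine, would compare at the end of these chains.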